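Shortening the Ether Chain on a Shared Core

The source may hold more compounds than are shown below. What is called first, only, known or untested is meant among the compounds shown, and "the series" means these compounds.

Measured so far:
compound 1 `Nc1ccc2cccc(OCCC3CCCCC3)c2n1`, giving 808 nM in an assay on cells with melanin-concentrating hormone receptor 1 (Homo sapiens) as the target, read by radioligand binding; a higher number here means a weaker inhibitor, a lower number a stronger inhibitor
compound 2 `CCCCOc1cccc2ccc(N)nc12`, giving 789 nM in this assay

Both compounds share one core with an aromatic amine, and differ only in the chain hanging from the ring oxygen. Within the data shown here, the one step between them, a 1.0-fold lower number from compound 1 to compound 2 (0.01 log units; within the scatter), shows that swapping the large ring-bearing chain for a plain butyl chain left the number where it was. Compound 2 therefore sits alongside compound 1, the two within the scatter of each other, and nothing in these two numbers sets one apart from the other.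

Compound 3 `CCCOc1cccc2ccc(N)nc12` continues along the same chain. The difference from compound 2 is hydrogen in place of methyl on a saturated chain carbon, three bonds along the chain from an oxygen on an aromatic ring, so the butyl chain becomes a propyl chain. Among the measured compounds shown here, only one measured step bears on this, the step from compound 1 to compound 2, and it was flat. That step removed a great deal from the chain without effect, which suggests that taking off a single carbon should also change little. The expected step is a 1.4-fold higher number from compound 2 to compound 3 (0.14 log units; within the scatter), not beyond the scatter. Compound 3 is estimated to give 1100 nM in this assay, with a range from 400 nM to 3500 nM.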

Compound 3, half-maximal inhibitory concentration: 1100 nM
Compound 3: middle estimate and measured number agree at the digits printed; measured number inside the range.
By their numbers in this assay, from the lowest: compounds 2, 1 and 3 (each within the scatter of the next).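

Cutting the butyl chain to a propyl chain gives a 1.4-fold higher number from compound 2 to compound 3 (0.14 log units; within the scatter) in this assay, so the loss of this end methyl, like the larger change before it, does not move the number past the usual spread of repeat measurements. The other new step, a 1.4-fold higher number from compound 1 to compound 3 (0.13 log units; within the scatter), also stays within that spread, which means the cyclohexyl-bearing chain, the butyl chain and the propyl chain cannot be told apart in this assay, and across these three compounds neither chain length nor the end ring shows a measurable link to the number. No independent measurement is available to explain why the number stays level across these chains.

The compounds shown leave open whether this flat picture lasts if the chain on the oxygen becomes shorter still, as an ethyl or a methyl group, or if it ends in an amine or a carboxylic acid. They also leave open what the aromatic amine contributes, as it stays the same in all three compounds.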